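The compounds below may be only part of what the source reports. "The series", "measured", "known", "first", "only" and "open" are said of these compounds alone.

Working notes on the series, read in an ADME assay on microsomes from liver (Homo sapiens) for metabolic stability, read by LC-MS, with a stated time of 30 min, tested at 0.1 uM; a lower number here means that less of the compound is left, a higher number that more of the compound is left. Compound 1 `FC(F)(F)Oc1ccc(-c2nc3cnc(Nc4ccccn4)cc3[nH]2)cc1` gives 60%, compound 3 `Fc1ccc(-c2nc3cnc(Nc4ccccn4)cc3[nH]2)cc1C(F)(F)F` gives 70%, and compound 2 `COc1ccnc(Nc2cc3[nH]c(-c4cccc(C(F)(F)F)c4)nc3cn2)c1` gives 80%. Compound 2 stands above compound 1 by a gap beyond the scatter, and it cannot be separated from compound 3, as that gap lies within the scatter. No two of these compounds differ in one place only, so no measured step bears directly on the next comparison.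

Compound 4 `Fc1cnc(Nc2cc3[nH]c(-c4cccc(C(F)(F)F)c4)nc3cn2)c(F)c1` is the next one to be read in this assay. It differs from compound 2 in a single place, with 3,5-difluoropyridin-2-yl in place of 4-methoxypyridin-2-yl on a nitrogen on an aromatic ring. For the measured compounds named here, the data hold no precedent for this exchange, so the expectation rests only on the spread of the three values and on compound 2 at 80% as the starting point. A small downward move is expected, not beyond the scatter. The expected step is a number 8 percentage points lower from compound 2 to compound 4 (within the scatter). For compound 4 the estimated value is 72%, with an expected range of 50% to 88%.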

Compound 4, percent of the compound remaining: 32%
Compound 4: middle estimate off by 40 percentage points, on the high side, and the stated range ends above it.
By their numbers in this assay, from the lowest: compound 4; then compounds 1, 3 and 2 (each within the scatter of the next, the first and the last beyond it).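

In this assay, for the compounds shown here, 3,5-difluoropyridin-2-yl in place of 4-methoxypyridin-2-yl on a nitrogen on an aromatic ring gives a number 48 percentage points lower from compound 2 to compound 4 (beyond the scatter), the first step that can be read across a single place. This position is therefore far from indifferent on the core of compound 2: the read-out moves strongly towards less of the compound being left, even though the leaving and entering groups have the same count of heavy atoms and the same kind of ring. Nothing measured here accounts for the size of this step.

The compounds shown leave open whether the step follows the loss of the methoxy group, the entry of the fluorines or both together, as the exchange changes these at once. On these data alone, how an unsubstituted pyridin-2-yl, a pyridin-2-yl bearing a single fluorine, or one bearing a dimethylamino group would read on the core of compound 2 also remains open, and these would show which part of the exchange carries the step.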